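The source may hold more compounds than are shown below. What is called first, only, known or untested is meant among the compounds shown, and "the series" means these compounds.

Compound 3 `O=C(COc1ccc2cc(/C=C3/SC(=O)NC3=O)ccc2c1)Nc1ccc([N+](=O)[O-])cc1` holds the lowest number of the three measured in an assay on isolated protein for inhibition of histone deacetylase 4 (Homo sapiens), with a stated time of 1 h (on this read-out lower numbers stand for stronger inhibition and higher numbers for weaker inhibition), where compound 3 gives 1700 nM. Its nearest neighbour is compound 2 `O=C(COc1ccc2cc(/C=C3/SC(=O)NC3=O)ccc2c1)Nc1cccc(C(F)(F)F)c1`, which in this assay gives 2500 nM; the gap a 1.5-fold lower number from compound 2 to compound 3 (0.17 log units; within the scatter) is within the scatter, so the two cannot be ordered. Compound 1 `O=C(COc1ccc2cc(/C=C3/SC(=O)NC3=O)ccc2c1)Nc1ccccn1` stands furthest, giving 17000 nM in this assay.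

The next compound, compound 4 `Cc1cccc(NC(=O)COc2ccc3cc(/C=C4/SC(=O)NC4=O)ccc3c2)n1`, differs from compound 3 by 6-methylpyridin-2-yl in place of 4-nitrophenyl on an amide-type nitrogen. The step that bears most directly on it is the reverse of the measured one, a 10-fold lower number from compound 1 to compound 3 (1.00 log units; beyond the scatter), since compound 1 carries the unsubstituted pyridin-2-yl on the same amide-type nitrogen; the step of a 6.8-fold lower number from compound 1 to compound 2 (0.83 log units; beyond the scatter) points the same way. Among the measured compounds shown here, no measured pair shows the effect of the methyl on the pyridin-2-yl, so the estimate rests on compound 1 alone and is given a wide range. For compound 4 a step of a 7.1-fold higher number from compound 3 to compound 4 (0.85 log units; beyond the scatter) is therefore expected in this assay, toward a higher number. Compound 4 is estimated at 12000 nM, within 4000 nM to 35000 nM.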

Compound 4, half-maximal inhibitory concentration: 1100 nM
Compound 4: the middle estimate sits 11-fold (1.04 log units) above what was measured; measured number below the stated range.
By their numbers in this assay, from the lowest: compounds 4, 3 and 2 (each within the scatter of the next, the first and the last beyond it); then compound 1.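

A methyl in place of hydrogen on an aromatic carbon gives a 15-fold lower number from compound 1 to compound 4 (1.19 log units; beyond the scatter) in this assay, so the high number of compound 1 does not belong to the pyridine ring as such. With 6-methylpyridin-2-yl on the amide-type nitrogen, the series reaches the range of the substituted phenyl groups: a 1.5-fold lower number from compound 3 to compound 4 (0.19 log units; within the scatter) leaves compound 3 and compound 4 unordered, while a 2.3-fold lower number from compound 2 to compound 4 (0.36 log units; beyond the scatter) is a modest step beyond the scatter. No evidence is available to account for the size of the methyl step.

Still open, on these data alone, is whether this step is specific to methyl or would also appear with an ethyl, a chlorine or a methoxy group on the pyridin-2-yl ring. Also open, as far as these compounds go, is how an amine or a carboxylic acid on that ring would read in this assay.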